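This account rests on a few compounds, and the source may have more. Where it says the series, first, only, none or still open, it means among the compounds named here.

Working notes on the series. The three measured compounds share one core and differ in the carbonyl substituent on it and in the amide-bearing tail. Compound 1 `COC(=O)c1cc2cc(NCc3cc(NC(=O)c4ccnc(C)c4)ccc3C)cnc2[nH]1` carries a methoxycarbonyl and an amine-linked tail; in a functional assay on HUVEC cells (Homo sapiens), read by MTT assay, with a stated time of 72 h (on this read-out lower numbers stand for an effect already at smaller amounts and higher numbers for an effect only at larger amounts of compound), compound 1 gives 986 nM. Compound 2 `COC(=O)c1cc2cc(CCc3cc(NC(=O)c4ccc(CN5CCC(N(C)C)C5)c(C(F)(F)F)c4)ccc3C)cnc2[nH]1` keeps the methoxycarbonyl, links its tail through a two-carbon chain and carries a trifluoromethyl; in this assay compound 2 gives 171 nM. Compound 3 `CC(=O)c1cc2cc(CCc3cc(NC(=O)c4ccc(CN5CCN(C)CC5)cc4)ccc3C)cnc2[nH]1` has an acetyl and a different amine in its tail; in this assay compound 3 gives 118 nM. Compound 2 thus stands second highest of the three numbers: its value and that of compound 3 lie within the scatter of each other, whereas compound 1 sits higher, beyond the scatter.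

Compound 4 `CC(=O)c1cc2cc(CCc3cc(NC(=O)c4ccc(CN5CCC(N(C)C)C5)c(C(F)(F)F)c4)ccc3C)cnc2[nH]1` is compound 2 with a single alteration: methyl in place of methoxy on a carbonyl carbon. Among the measured compounds shown here, no measured pair isolates this alteration. Compound 3 carries the same acetyl and a number close to that of compound 2, but its tail differs as well, so the two changes cannot be separated on the data in hand. The expectation for this assay is a 1.1-fold lower number from compound 2 to compound 4 (0.06 log units; within the scatter), that is, no step beyond the scatter in either direction. Compound 4 is accordingly estimated at 150 nM, with a range from 60 nM to 400 nM.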

Compound 4, half-maximal effective concentration: 163 nM
Estimate against measurement, compound 4: 1.1-fold (0.04 log units) below, and the stated range covers the measured number.
By their numbers in this assay, from the lowest: compounds 3, 4 and 2 (each within the scatter of the next); then compound 1.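

In this assay, the change of methoxy to methyl on a carbonyl carbon can now be read on its own, with the tail held constant, and it gives a 1.0-fold lower number from compound 2 to compound 4 (0.02 log units; within the scatter). On the tail of compound 2, methoxycarbonyl and acetyl therefore cannot be told apart in this assay: the methoxy leaves with its oxygen and its hydrogen-bond acceptor, and no step beyond the scatter follows. No separate evidence bears on this result.

The compounds shown leave open whether any other group on this carbonyl carbon would also stay within the scatter, for instance an amine, which would give an amide, a hydroxyl, which would give a carboxylic acid, or a longer chain such as ethyl or ethoxy. Going by these compounds, it also remains open whether the same change reads alike on another tail, such as that of compound 1 or compound 3, since this single step rests on the tail of compound 2 alone.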